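Taking the chloro off compound 1

A few compounds are considered here, and "the series" means these few. Any claim that something is new, unique, unknown or untested is made for them only; others in the source may bear on it.

Compound 1 (`COc1cc([C@@H]2C[C@]2(CO)C(=O)Nc2ccccc2Cl)cc(OC)c1OC`) gives 13200 nM
Compound 2 (`CCOC(=O)[C@]1(C(=O)Nc2ccccc2Cl)C[C@H]1c1cc(OC)c(OC)c(OC)c1`) gives 25600 nM
Compound 3 (`COc1cc([C@@H]2C[C@@]2(CO)C(=O)Nc2ccccc2Cl)cc(OC)c1OC`) gives 10700 nM

In a functional assay on SW480 cells (Homo sapiens) for cytotoxicity, read by MTT assay, with a stated time of 48 h (on this read-out lower numbers stand for stronger inhibition and higher numbers for weaker inhibition), compound 1 stands at 13200 nM and both other measured compounds lie within the usual scatter of it. Compound 4 (`COc1cc([C@@H]2C[C@]2(CO)C(=O)Nc2ccccc2)cc(OC)c1OC`) differs from compound 1 by hydrogen in place of chloro on an aromatic carbon. For the measured compounds named here, two measured steps bear on this only indirectly (a 1.9-fold higher number from compound 1 to compound 2 (0.29 log units; within the scatter); a 1.2-fold lower number from compound 1 to compound 3 (0.09 log units; within the scatter)) since both stay within the scatter and both alter other parts of the molecule, leaving the chloro in place. Going by the values given here, no measured step therefore gives a direction, and no shift beyond the scatter is expected in this assay. The expected change is small (a 1.2-fold higher number from compound 1 to compound 4 (0.08 log units; within the scatter)) and stays within the scatter. Compound 4 is estimated at 16000 nM (expected range 7000 nM to 40000 nM).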

Compound 4, half-maximal inhibitory concentration: 33300 nM
Compound 4: middle estimate off by 2.1-fold (0.32 log units), on the low side, and the stated range covers the measured number.
By their numbers in this assay, from the lowest: compounds 3, 1, 2 and 4 (each within the scatter of the next, the first and the last beyond it).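

In this assay, for the compounds shown here, hydrogen in place of chloro gives the first step here beyond the scatter (a 2.5-fold higher number from compound 1 to compound 4 (0.40 log units; beyond the scatter)), a modest one, whereas the changes elsewhere on compound 1 stayed within it. The aromatic carbon that carries the chloro is therefore a place where this read-out responds, and the compound keeping the chloro, compound 1, gives the lower number. Nothing given here bears on why this step has its size.

Only chloro and hydrogen are shown at this place, so it remains open how fluoro, methoxy or an amine there would compare. From the compounds shown here alone, it also remains open whether removing the chloro from compound 3 would give a similar step.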